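The source may hold more compounds than are shown below. What is called first, only, known or untested is meant among the compounds shown, and "the series" means these compounds.

Measured so far:
- compound 1 `COc1ccc(-c2cc(/C=C/C(=O)c3ccc(N)cc3)[nH]n2)cc1`: 36%
- compound 2 `COc1cc(-c2cc(/C=C/C(=O)c3ccc(N)cc3)[nH]n2)cc(OC)c1OC`: 28%

In a functional assay on RPMI-8226 cells (Homo sapiens) for cytotoxicity, read by sulforhodamine B assay, with a stated time of 48 h, tested at 1 uM (a lower number here means a stronger effect, a higher number a weaker effect of the compound at the concentration tested), compound 2 stands at the lowest of the two numbers, yet compound 1 lies within the scatter of it, so no order is read into the pair. Compound 3 `COc1ccc(-c2cc(/C=C/C(=O)c3ccc(N)cc3)[nH]n2)cc1OC` differs from compound 2 by hydrogen in place of methoxy on an aromatic carbon. Among the compounds with values here, no step between measured compounds is known, and the two values on hand sit within scatter of each other, so no step beyond the scatter is expected here in either direction. Compound 3 is expected to give 32%, range 20% to 45%, an estimated step of a number 4 percentage points higher from compound 2 to compound 3 (within the scatter) within the scatter.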

Compound 3, a percentage reported as activity, at one concentration (the size of the read-out at that concentration, not a potency): 59%
Estimate against measurement, compound 3: 27 percentage points below; measured number outside the range, above it.
By their numbers in this assay, from the lowest: compounds 2 and 1 (each within the scatter of the next); then compound 3.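

In this assay this aromatic carbon proves sensitive to its substituent: hydrogen in place of methoxy gives a number 31 percentage points higher from compound 2 to compound 3 (beyond the scatter), and methoxy in place of hydrogen gives a number 23 percentage points higher from compound 1 to compound 3 (beyond the scatter). The same kind of change therefore does not act in one direction across the series, since compound 3 stands apart from both neighbours while compound 1 and compound 2 lie within the scatter of each other. The data on hand offer no explanation for this.

Open, from the compounds shown here alone, is whether a hydroxy group or a chlorine atom on this carbon would match compound 2 or compound 3. Also open, going by these compounds, is whether the gap persists at other concentrations.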